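The source may report more compounds than this note shows. Statements on the series, on what has been measured and on what is new or still open speak of the compounds shown alone.

Working notes on the series, read in a functional assay on HeLa cells (Homo sapiens) for inhibition, read by MTT assay, with a stated time of 48 h; on this read-out lower numbers stand for stronger inhibition and higher numbers for weaker inhibition.

Compound 1 `Brc1ccc(C(c2c[nH]c3ccc(Br)cc23)c2c[nH]c3ccc(Br)cc23)cc1` gives 1500 nM. Compound 2 `O=[N+]([O-])c1ccc(C(c2c[nH]c3ccc(Br)cc23)c2c[nH]c3ccc(Br)cc23)cc1` carries the change (nitro in place of bromo on an aromatic carbon), and in this assay compound 2 gives 1500 nM. The step of no change at the digits printed from compound 1 to compound 2 (within the scatter) is therefore flat: within this pair the substitution leaves the read-out where it was.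

Compound 3 `O=[N+]([O-])c1ccc2[nH]cc(C(c3ccc(Br)cc3)c3c[nH]c4ccc([N+](=O)[O-])cc34)c2c1` is a different core; the difference between the two cores is not broken down here. In this assay compound 3 reports only a limit, > 100000 nM, and not a number. That limit is the one described as the limit of > 100000 nM in this assay, at which 1 of the 3 values shown sits.

Compound 4 `O=[N+]([O-])c1ccc(C(c2c[nH]c3ccc([N+](=O)[O-])cc23)c2c[nH]c3ccc([N+](=O)[O-])cc23)cc1` stands to compound 3 as compound 2 stands to compound 1: the change (nitro in place of bromo on an aromatic carbon). The place line reads the same word for word in both pairs, so this is the same change made on the second core, and it occurs twice among the compounds here.

Expectation for compound 4: the only measured instance of this change, on the first core, moved nothing, and the parent on the second core sits at a limit. That rests on no change at the digits printed from compound 1 to compound 2 (within the scatter) and on the limit of compound 3. The expected step is a step that the limit leaves unreadable from compound 3 to compound 4. Compound 4 is estimated at 150000 nM, with the likely range spanning 30000 nM to 1000000 nM, and the most probable outcome is that this assay again returns a limit rather than a number. What the measurement shows follows.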

Compound 4, half-maximal inhibitory concentration: > 100000 nM
Compound 4: no number, only a limit (the forecaster's own chance of this, stated with the estimate: 80%); the middle value is on the limit's open side.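

In this assay compound 4 gives > 100000 nM, a limit and not a number. Compound 3 also reports only a limit, so no step can be read between compound 3 and compound 4: the limit of > 100000 nM in this assay, at which 2 of the 4 values shown sit.

The compounds shown leave open whether nitro in place of bromo on the core of compound 3 moves the read-out at all, as it did not from compound 1 to compound 2.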